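The source may report more compounds than this note shows. Statements on the series, on what has been measured and on what is new or still open speak of the compounds shown alone.

Working notes on a series built on a shared core carrying an arylsulfonamide at one end and an aroyl amide at the other. In an assay on MDA-MB-231 cells for binding affinity to C-X-C chemokine receptor type 4 (Homo sapiens), read by immunofluorescence and microscopy, with stated times of 10 min and 30 min (on this read-out lower numbers stand for an effect already at smaller amounts and higher numbers for an effect only at larger amounts of compound), compound 1 `Cc1ccc(S(=O)(=O)NCc2ccc(CNC(=O)c3ccc([N+](=O)[O-])cc3)cc2)cc1` gives 10 nM, compound 2 `COc1ccccc1C(=O)NCc1ccc(CNS(=O)(=O)c2ccccc2)cc1` gives 1 nM and compound 3 `O=C(NCc1ccc(CNS(=O)(=O)c2ccccc2)cc1)c1c(Cl)cc(Cl)cc1Cl` gives 10 nM. Compound 1 is level with compound 3 at the digits shown, the pair standing highest of the three, while compound 2 sits lower; the only measured step is a 10-fold higher number from compound 2 to compound 3 (1.00 log units; beyond the scatter). Compound 4 `Cc1ccc(C(=O)NCc2ccc(CNS(=O)(=O)c3ccc(C)cc3)cc2)cc1` differs from compound 1 in one place: methyl in place of nitro on an aromatic carbon. The measured step also alters the ring on the carbonyl carbon, but exchanges that ring wholesale rather than one group on it, so it bears only loosely here and the expected step is no change at the digits printed from compound 1 to compound 4 (within the scatter), none beyond the scatter. Compound 4 is therefore estimated at 10 nM, within 3 nM to 30 nM.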

Compound 4, effective concentration (reported as EC, without a stated level of effect): 1000 nM
Beside the measured number, compound 4's estimate is 100-fold (2.00 log units) below it; measured number above the stated range.
By their numbers in this assay, from the lowest: compound 2; then compounds 1 and 3 (each within the scatter of the next); then compound 4.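

In this assay the change from nitro to methyl on an aromatic carbon, para to a large group, gives a 100-fold higher number from compound 1 to compound 4 (2.00 log units; beyond the scatter) and shows that this position is far from indifferent to its group. The earlier step exchanged a whole ring, whereas here a single group on the ring is enough for a large step. No measurement at hand accounts for its size. Open, going by these compounds, is where an amine, a carboxylic acid or a halogen at this position would fall. Also open, on these data alone, is whether the same change gives a step of this size with the other arylsulfonamide end seen in compound 2.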